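This account rests on a few compounds, and the source may have more. Where it says the series, first, only, none or still open, it means among the compounds named here.

Compound 1 `C[C@H](Cc1ccccc1)C(=O)SCCCCCCC(=O)Nc1nc(-c2ccccc2)cs1`: 3200 nM
Compound 2 `CC(Cc1ccccc1)C(=O)SCCCCCCC(=O)Nc1nc(-c2ccccc2)cs1`: 1500 nM
Compound 3 `COC(C(=O)SCCCCCCC(=O)Nc1nc(-c2ccccc2)cs1)c1ccccc1`: 11000 nM

In a functional assay on NCI-H460 cells (Homo sapiens) for inhibition (a lower number here means that less compound is needed, a higher number that more compound is needed for the effect), compound 2 has the lowest number of the three, at 1500 nM. Compound 4 `O=C(CCCCCCSC(=O)C(Cc1ccccc1)Cc1ccccc1)Nc1nc(-c2ccccc2)cs1` differs from compound 2 in one place: phenyl in place of hydrogen on a saturated chain carbon, two bonds along the chain from a carbonyl carbon. This puts phenyl in place of hydrogen on a saturated chain carbon, two bonds along the chain from a carbonyl carbon. Cut one bond further out, the same difference reads methyl to benzyl.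

Going by the values given here, no measured step makes this exact change. The step of a 2.1-fold lower number from compound 1 to compound 2 (0.33 log units; beyond the scatter) comes with the fact that one of compounds 1 and 2 is drawn with a defined configuration and the other without, at the place where they differ, so it says little about adding phenyl. The closest evidence is a 7.3-fold higher number from compound 2 to compound 3 (0.87 log units; beyond the scatter), and a 3.4-fold higher number from compound 1 to compound 3 (0.54 log units; beyond the scatter) points the same way. Both replace 1-benzylethyl with methoxy(phenyl)methyl on a carbonyl carbon.

Going by a 7.3-fold higher number from compound 2 to compound 3 (0.87 log units; beyond the scatter), a modest rise is expected in this assay, though this is only a loose guide. The expected change is a 2.3-fold higher number from compound 2 to compound 4 (0.37 log units; beyond the scatter). For compound 4 the estimated value is 3500 nM, with an expected range from 900 nM to 12000 nM.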

Compound 4, half-maximal effective concentration: > 20000 nM
Compound 4 ended at the assay's limit; the forecaster's own chance of this, stated with the estimate: 5%; middle value at least 5.7-fold (0.75 log units) away from the limit.
By their numbers in this assay, from the lowest: compound 2; then compound 1; then compound 3. At a limit, above all of these: compound 4.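

On the saturated chain carbon two bonds along the chain from a carbonyl carbon, phenyl in place of hydrogen, which reads as methyl to benzyl, gives an at least 13-fold higher number from compound 2 to compound 4 (1.12 log units; beyond the scatter) in this assay. For compound 4, the reading > 20000 nM is a limit of the assay and not a number. The earlier steps shown here changed the whole group on the carbonyl carbon and were modest, whereas this single added ring at one carbon makes a large step, so the number in this assay responds strongly to what sits at this position.

Going by these compounds, how an ethyl or an aminomethyl group would behave at this carbon stays open. Going by these compounds alone, the role of configuration there also stays open, as the only step touching it carries a caveat: the fact that one of compounds 1 and 2 is drawn with a defined configuration and the other without, at the place where they differ.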